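A few compounds are considered here, and "the series" means these few. Any claim that something is new, unique, unknown or untested is made for them only; others in the source may bear on it.

Measured so far:
compound 1 `Cc1oc(-c2ccccc2)nc1CN1CCCC(C(=O)NCC2CCOCC2)C1`: 105 mL.min-1.g-1
compound 2 `Cc1cccc(CNC(=O)[C@H]2C[C@H](c3nc(C)no3)CN(Cc3nc(-c4ccccc4)oc3C)C2)n1`: 290 mL.min-1.g-1
compound 3 `COC[C@H]1C[C@@H](C(=O)NC[C@H]2CCCO2)CN(Cc2nc(-c3ccccc3)oc2C)C1`: 40.3 mL.min-1.g-1

All three were run in an in vitro ADME assay on microsomes from liver (Homo sapiens) for metabolic stability; on this read-out lower numbers stand for slow clearance and higher numbers for fast clearance. Compound 2 stands highest of the three numbers: compound 1 is nearest, with a lower number, and compound 3 is furthest, with a still lower number, both gaps beyond the usual scatter. Compound 4 `Cc1cccc(CNC(=O)[C@@H]2C[C@@H](c3nc(C)no3)CN(Cc3nc(-c4ccccc4)oc3C)C2)n1` has not yet been measured. It differs from compound 2 in this way: the two compounds have the same atoms and bonds and differ only in configuration as drawn: 2 of 2 stereo elements differ (all stereocentres are inverted: mirror images); a stereocentre at a saturated ring carbon is drawn S in compound 2 and R in compound 4; a stereocentre at a saturated ring carbon is drawn S in compound 2 and R in compound 4. Going by the values given here, no pair of measured compounds shows what a change of configuration alone does here, so there is no step to lean on. A step from compound 2 to compound 4 of no size beyond the scatter is therefore expected, in either direction. The expected step is a 1.2-fold lower number from compound 2 to compound 4 (0.06 log units; within the scatter). Compound 4 is expected to give 250 mL.min-1.g-1, between 100 mL.min-1.g-1 and 600 mL.min-1.g-1.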

Compound 4, intrinsic clearance in microsomes: 105 mL.min-1.g-1
Beside the measured number, compound 4's estimate is 2.4-fold (0.38 log units) above it; the measured number falls inside the stated range.
By their numbers in this assay, from the lowest: compound 3; then compounds 1 and 4 (each within the scatter of the next); then compound 2.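

Inverting both stereocentres, with atoms and bonds unchanged, gives a 2.8-fold lower number from compound 2 to compound 4 (0.44 log units; beyond the scatter) in this assay and so moves clearance beyond the scatter. Configuration at these saturated ring carbons therefore matters in this series, which the earlier compounds, differing in several places at once, could not show. The shift can be traced to configuration alone: the fact that compounds 2 and 4 differ only in the configuration as drawn.

Whether one inverted stereocentre would account for the whole step remains open. So does whether the same inversion would matter with a carboxylic acid or an amine on the shared core.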